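Amide Ring Variation and an Expected Limit for Compound 4

A few compounds are considered here, and "the series" means these few. Any claim that something is new, unique, unknown or untested is made for them only; others in the source may bear on it.

Measured compounds:
- compound 1, `CC(C(=O)N1CC2CC2C1)N1CCN(S(=O)(=O)c2ccc(C(C)(C)C)cc2)CC1`: > 40000 nM
- compound 2, `CC(C(=O)N1CCCCC1)N1CCN(S(=O)(=O)c2ccc(C(C)(C)C)cc2)CC1`: > 40000 nM
- compound 3, `CC(C(=O)N1CCCCCC1)N1CCN(S(=O)(=O)c2ccc(C(C)(C)C)cc2)CC1`: > 40000 nM

In an ADME assay on HepG2 cells (Homo sapiens) for inhibition, with a stated time of 48 h (a lower number here means that less compound is needed, a higher number that more compound is needed for the effect), compound 1 gives > 40000 nM, which is a limit of the assay and not a number. Compound 2 likewise gives > 40000 nM in this assay, again a limit. Compound 3 gives > 40000 nM in this assay, also a limit. Because all three results sit at the same limit, as the limit of > 40000 nM in this assay, at which 3 of the 3 values shown sit, records, the steps a step that the two limits leave unreadable from compound 1 to compound 2, a step that the two limits leave unreadable from compound 1 to compound 3 and a step that the two limits leave unreadable from compound 2 to compound 3 cannot be read in size or direction.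

Compound 4 is `CC(C(=O)N1CCC(F)(F)CC1)N1CCN(S(=O)(=O)c2ccc(C(C)(C)C)cc2)CC1`. It differs from compound 3 by 4,4-difluoropiperidin-1-yl in place of azepan-1-yl on a carbonyl carbon. Among the measured compounds shown here, the only measured steps that bear on it are the three unreadable ones above, all changes of the amide ring on the same carbonyl carbon, and none of them produced a number below the limit. Compound 4 is therefore expected to behave like its neighbours, and the step that the limit leaves unreadable from compound 3 to compound 4 is estimated to be no more than the scatter, with a high chance that the assay again reports only a limit. The estimate for compound 4 in this assay is 60000 nM, within a range from 20000 nM to 200000 nM.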

Compound 4, half-maximal effective concentration: > 40000 nM
Compound 4 ended at the assay's limit; the forecaster's own chance of this, stated with the estimate: 85%; the middle value lies beyond the limit too.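

Compound 4 gives > 40000 nM in this assay, which is a limit of the assay and not a number. Its steps from compound 1, compound 2 and compound 3 therefore cannot be read in size or direction: the limit of > 40000 nM in this assay, at which 4 of the 4 values shown sit.

The compounds shown leave open whether any amide ring on this carbonyl carbon gives a readable value in this assay.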